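The source may hold more compounds than are shown below. What is called first, only, known or untested is meant among the compounds shown, and "the series" means these compounds.

Measured so far in an ADME assay on Huh-7 cells (Homo sapiens) for cytotoxicity, with a stated time of 3 days; a lower number here means that less compound is tolerated, a higher number that more compound is tolerated:

- compound 1, `O=C(NC1CCCCC1)c1c(NO)cc(-c2ccc(F)cc2)oc1=O`, gives 11400 nM
- compound 2, `O=C(NC1CCCCC1)c1c(NO)cc(-c2ccc(Cl)cc2)oc1=O`, gives 8800 nM
- compound 3, `O=C(Nc1ccc(F)cc1)c1c(NO)cc(-c2cccs2)oc1=O`, gives > 20000 nM, which is a limit of the assay and not a number

Compound 1 and compound 2 share one core and differ in a single place: chloro in place of fluoro on an aromatic carbon. That change made a 1.3-fold lower number from compound 1 to compound 2 (0.11 log units; within the scatter), so on this core the two values cannot be told apart.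

Compound 4, `O=C(Nc1ccc(Cl)cc1)c1c(NO)cc(-c2cccs2)oc1=O`, has not yet been measured in this assay. It stands to compound 3 as compound 2 stands to compound 1: chloro in place of fluoro on an aromatic carbon. The place of the change reads the same in both pairs, so it is the same change made on a different core. The difference between the core of compound 1 and the core of compound 3 is not broken down here.

Going by the values given here, the one measured instance of this change gave a step within the scatter, and compound 3 sits at the limit of > 20000 nM in this assay, at which 1 of the 3 values shown sits. On that basis the step from compound 3 to compound 4 is expected to be about as small, a number no higher from compound 3 to compound 4 (the limit leaves the size open), and compound 4 is expected to come out near 20000 nM in this assay, most likely again reported only as a limit rather than as a number, with a range of roughly 11000 nM to 40000 nM.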

Compound 4, half-maximal cytotoxic concentration: > 20000 nM
Compound 4 ended at the assay's limit (the forecaster's own chance of this, stated with the estimate: 70%); the middle value sits exactly at the limit.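

Going by these compounds alone, compound 3 and compound 4 both give only a limit in this assay, not a number, so no step between them can be read. The compounds shown leave open whether chloro in place of fluoro on an aromatic carbon changes the number as little on the core of compound 3 as it does on the core of compound 1.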